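The compounds below may be only part of what the source reports. "The series", "measured", "known", "first", "only" and "open" are said of these compounds alone.

Measured compounds and their values in a functional assay on CHO cells for positive allosteric modulation of muscarinic acetylcholine receptor M5 (Homo sapiens), read by calcium flux; a higher number here means a larger maximal response, a lower number a smaller maximal response:
compound 1, `CCN(Cc1ccccc1)C(=O)C1CCN(S(=O)(=O)c2ccc(OC)c(OC)c2)CC1`: 57%
compound 2, `CCN(Cc1ccccc1)C(=O)C1CCN(S(=O)(=O)c2ccc3nsnc3c2)CC1`: 81%
compound 3, `CCCN(Cc1ccccc1C(F)(F)F)C(=O)C1CCN(S(=O)(=O)c2ccc3[nH]ncc3c2)CC1`: 94%

Among these three, compound 3 stands highest in this assay; compound 2 is the nearest to it, and compound 1 is furthest below. Among the measured compounds shown here, the only single-point step measured so far is a number 24 percentage points higher from compound 1 to compound 2 (beyond the scatter), a change of the ring system on the sulfonyl sulfur. For the measured compounds named here, compounds 2 and 3 differ in several places at once, so their two values show only that compound 3 lies higher; no step is known for them.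

Compound 4, `O=C(C1CCN(S(=O)(=O)c2ccc3[nH]ncc3c2)CC1)N(Cc1ccccc1C(F)(F)F)CC1CC1`, differs from compound 3 in one place: cyclopropyl in place of ethyl on a saturated chain carbon bound to an amide-type nitrogen. Going by the values given here, this change sits on the saturated chain carbon bound to the amide-type nitrogen, far from the sulfonyl sulfur where the one measured step was taken, so that step does not speak to it. With nothing measured on this part of the molecule, the expectation is a step in this assay of no size beyond the usual scatter, that is a number 4 percentage points lower from compound 3 to compound 4 (within the scatter). Compound 4 is therefore estimated to give 90% in this assay, with a range from 70% to 105%.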

Compound 4, largest response reached (reported as percent of maximum), in percent of the reference or control that the assay uses: 102%
Compound 4: middle estimate off by 12 percentage points, on the low side; the range from low to high includes it.
By their numbers in this assay, from the lowest: compound 1; then compound 2; then compounds 3 and 4 (each within the scatter of the next).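

In this assay, cyclopropyl in place of ethyl on a saturated chain carbon bound to an amide-type nitrogen gives a number 8 percentage points higher from compound 3 to compound 4 (within the scatter). Among the compounds shown here, this is the first measured step at this position, and it shows that a small closed ring can stand here in place of an open chain while the two compounds remain indistinguishable in maximal response. Nothing measured here offers an explanation for this result.

As far as these compounds go, whether a longer chain such as butyl, a larger ring such as cyclohexyl, or a chain ending in an amine or a carboxylic acid would be accepted here remains open. From the compounds shown here alone, it is also open whether cyclopropyl in place of ethyl would read the same with the group on the sulfonyl sulfur of compound 2.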